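The source may report more compounds than this note shows. Statements on the series, on what has been measured and on what is new or still open speak of the compounds shown alone.

Measured so far:
compound 1 `Cc1ccccc1-c1nn(-c2ccc(F)cc2F)cc1CN1CCN(c2ccccc2)CC1` — > 20000 nM
compound 2 `CN1CCN(CCNCc2cn(-c3ccc(C(F)(F)F)cc3)nc2-c2ccc(OC(F)(F)F)cc2)CC1` — 3000 nM
compound 3 `CN1CCN(CCNCc2cn(-c3ccc(F)cc3F)nc2-c2ccc(S(=O)(=O)N(C)C)cc2)CC1` — > 20000 nM

All three were tested in an ADME assay on Huh-7 cells (Homo sapiens) for cytotoxicity; a higher number here means that more compound is tolerated, a lower number that less compound is tolerated. The value for compound 1 is a limit of the assay, not a number. The value for compound 3 is likewise a limit. Compound 2 gives an actual number, 3000 nM. Compound 1 thus stands at the limit of > 20000 nM in this assay, at which 2 of the 3 values shown sit. Compound 4 `Cc1ccccc1-c1nn(-c2ccc(F)cc2F)cc1CN1CCN(C(C)C)CC1` has not yet been tested; it differs from compound 1 by isopropyl in place of phenyl on an amine nitrogen in a ring. Among the measured compounds shown here, no measured pair shows this change, so no size of step is known for it. The step from compound 1 to compound 4 is expected to be a step that the limit leaves unreadable from compound 1 to compound 4, within the scatter. Compound 4 is therefore expected to give 25000 nM, between 8000 nM and 60000 nM.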

Compound 4, half-maximal cytotoxic concentration: > 20000 nM
Compound 4 gave a limit, no number; the forecaster's own chance of this, stated with the estimate: 70%; the middle value is on the limit's open side.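

Among the compounds shown here, compound 1 and compound 4 each give only a limit of the assay, not a number, and no step between them can be read. Going by these compounds, whether isopropyl in place of phenyl changes anything in this assay stays open.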